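Series notes: from compound 3 to compound 4

A few compounds are considered here, and "the series" means these few. Any claim that something is new, unique, unknown or untested is made for them only; others in the source may bear on it.

Measured in an ADME assay on Karpas-1106P cells (Homo sapiens) for cytotoxicity; on this read-out lower numbers stand for an effect already at smaller amounts and higher numbers for an effect only at larger amounts of compound:
- compound 1 `COc1cc(OC)cc(C(=O)NCCNC(=O)[C@H](CC(=O)NC(C)(C)C)NS(=O)(=O)c2ccc(C)cc2)c1`: > 11100 nM, a limit
- compound 2 `Cc1ccc(S(=O)(=O)N[C@@H](CC(=O)NC(C)(C)C)C(=O)NCCNC(=O)c2cccc(F)c2)cc1`: > 11100 nM, a limit
- compound 3 `Cc1ccc(S(=O)(=O)N[C@@H](CC(=O)NC(C)(C)C)C(=O)NCCNC(=O)c2cc(Cl)ccc2Cl)cc1`: > 11100 nM, a limit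

Compound 3 stands at > 11100 nM, which is a limit and not a number. The series as a whole offers no measured number: the limit of > 11100 nM in this assay, at which 3 of the 3 values shown sit.

Compound 4 `Cc1ccc(S(=O)(=O)N[C@@H](CC(=O)NC(C)(C)C)C(=O)NCCNC(=O)c2ccc(F)c(F)c2)cc1` carries 3,4-difluorophenyl in place of 2,5-dichlorophenyl on a carbonyl carbon.

Three measured steps change the group at this same place: a step that the two limits leave unreadable from compound 1 to compound 2, a step that the two limits leave unreadable from compound 1 to compound 3 and a step that the two limits leave unreadable from compound 2 to compound 3. None of them has a readable size, so none gives a direction for the new change. Among the compounds with values here, no readable step is therefore expected in this assay, and compound 4 is expected to remain at the limit, like the three compounds measured so far.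

The expected change is nominal only, given as a step that the limit leaves unreadable from compound 3 to compound 4. The estimate for compound 4 is 14000 nM, with an expected range of 8000 nM to 30000 nM.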

Compound 4, half-maximal effective concentration: > 11100 nM
Compound 4 ended at the assay's limit (the forecaster's own chance of this, stated with the estimate: 85%); the middle value does not contradict the limit.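

Compound 4 gives > 11100 nM in this assay, which is a limit and not a number. Its steps from compound 1, compound 2 and compound 3 therefore cannot be read. Whether any group on the carbonyl carbon would shift this read-out stays open, with the whole series at one value: the limit of > 11100 nM in this assay, at which 4 of the 4 values shown sit.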